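This account rests on a few compounds, and the source may have more. Where it says the series, first, only, none or still open, it means among the compounds named here.

Compound 1 `CS(=O)(=O)CCCn1c(Cn2nc(S(C)(=O)=O)c3ccncc32)nc2cc(Cl)ccc21` gives 2 ug/mL in a physicochemical assay for solubility, read by spectrophotometry, in phosphate buffer, at pH 6.5; a higher number here means a more soluble compound, a lower number a less soluble compound. Compound 2 `CS(=O)(=O)c1nn(Cc2nc3cc(Cl)ccc3n2CCC(O)C(F)(F)F)c2cnccc12` gives in this assay only < 1 ug/mL, which is a limit of the assay and not a number. For the measured compounds named here, the one measured step, an at least 2.0-fold lower number from compound 1 to compound 2 (0.30 log units; that floor lies within the scatter), therefore carries a floor only. Compound 3 `CS(=O)(=O)c1nn(Cc2nc3cc(Cl)ccc3n2CCC(F)(F)F)c2cnccc12` differs from compound 2 by trifluoromethyl in place of 2,2,2-trifluoro-1-hydroxyethyl on a saturated chain carbon, two bonds along the chain from an aromatic nitrogen. No measured step covers this change, and compound 2 sits at the limit of < 1 ug/mL in this assay, at which 1 of the 2 values shown sits, so the numbers shown fix no size for it in this assay. Compound 3 is expected near 0.8 ug/mL, in the range 0.3 ug/mL to 3 ug/mL. The expected step is a step that the limit leaves unreadable from compound 2 to compound 3, quite possibly again only a limit.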

Compound 3, solubility: 3 ug/mL
Compound 3: the middle estimate sits 3.8-fold (0.57 log units) below what was measured; the measured number falls inside the stated range.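

For the compounds shown here, at this place, on a saturated chain carbon, two bonds along the chain from an aromatic nitrogen, trifluoromethyl gives the first step in this assay that clears the scatter: an at least 3.0-fold higher number from compound 2 to compound 3 (0.47 log units; beyond the scatter). That size is a floor only: the limit of < 1 ug/mL in this assay, at which 1 of the 3 values shown sits. Set against (methylsulfonyl)methyl, trifluoromethyl shows no separation: a 1.5-fold higher number from compound 1 to compound 3 (0.18 log units; within the scatter).

Going by these compounds, the full size of the step from compound 2 stays open. Also open, on these data alone, is whether an amine, a carboxylic acid or a longer chain at this place would separate from compound 1 and compound 3 in this assay.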